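The compounds below may be only part of what the source reports. "The series", "measured", "known", "first", "only" and "open" are said of these compounds alone.

Measured in an ADME assay on HEK293 cells (Homo sapiens) for cytotoxicity, read by luminescence, with a stated time of 72 h; a lower number here means that less compound is needed, a higher number that more compound is needed for the effect:

- Compound 1 `CCOC(=O)c1c(-c2cccc(F)c2)[nH]c2cc(OC)ccc2c1=O`: > 22000 nM
- Compound 2 `CCOC(=O)c1c(-c2cccc(-c3ccccc3)c2)[nH]c2cc(OC)c(F)cc2c1=O`: > 22000 nM
- Compound 3 `CCOC(=O)c1c(-c2cccc(OC(F)(F)F)c2)[nH]c2cc(OC)c(F)cc2c1=O`: > 22000 nM

Each of these entries is a limit of the assay and not a number. The picture so far is simple: the limit of > 22000 nM in this assay, at which 3 of the 3 values shown sit. Compound 3 therefore has no exact place on the scale, and its entry of > 22000 nM is a limit.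

Compound 4 `CCOC(=O)c1c(-c2cccc(F)c2)[nH]c2cc(OC)c(F)cc2c1=O` carries fluoro in place of trifluoromethoxy on an aromatic carbon, meta to a large group (fluoro in place of trifluoromethoxy on an aromatic carbon). Among the measured compounds shown here, one measured step bears on this, since it also exchanges a group on an aromatic carbon: a step that the two limits leave unreadable from compound 2 to compound 3. Its size cannot be read, so it offers no direction. No step beyond the scatter is therefore expected in this assay, and no direction is favoured. The expected step is a step that the limit leaves unreadable from compound 3 to compound 4. For compound 4 the estimated value is 30000 nM, with an expected range from 15000 nM to 60000 nM.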

Compound 4, half-maximal effective concentration: > 22000 nM
Compound 4 gave a limit, no number; the forecaster's own chance of this, stated with the estimate: 85%; the middle value lies beyond the limit too.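

Compound 4 gives > 22000 nM, which is a limit of the assay and not a number. The steps from compound 1, compound 2 and compound 3 to compound 4 cannot be read. The compounds shown leave open where any of these four lies on the scale of this assay.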